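The source may report more compounds than this note shows. Statements on the series, on what has been measured and on what is new or still open speak of the compounds shown alone.

Compound 1 `CC(=O)Nc1ccc(S(=O)(=O)Nc2cccc(-c3nc(-c4ccc(NC(=O)c5cccnc5)cc4Cl)no3)c2)cc1C` — in a functional assay on MDA-MB-231 cells (Homo sapiens) for antiproliferative activity, read by MTT assay, with a stated time of 72 h (a higher number here means a weaker inhibitor, a lower number a stronger inhibitor), compound 1 gives > 10000 nM, which is a limit of the assay rather than a number.
Compound 2 `NC(=O)Nc1ccc(S(=O)(=O)Nc2cccc(-c3nc(-c4ccc(NC(=O)c5cccnc5)cc4Cl)no3)c2)cc1` — in this assay compound 2 gives 2800 nM.

Compound 2 therefore holds the only actual number in this assay; the other shown value is the limit of > 10000 nM in this assay, at which 1 of the 2 values shown sits. For the measured compounds named here, the one measured step, an at least 3.5-fold lower number from compound 1 to compound 2 (0.55 log units; beyond the scatter), changes the aryl group carried on the sulfonyl sulfur and leaves the urea untouched.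

Compound 3 `CCNC(=O)Nc1ccc(S(=O)(=O)Nc2cccc(-c3nc(-c4ccc(NC(=O)c5cccnc5)cc4Cl)no3)c2)cc1` differs from compound 2 by ethyl in place of hydrogen on an amide-type nitrogen. Going by the values given here, no measured step touches that amide-type nitrogen, so the measured step offers no direct guide to this change, and it lies on a different part of the molecule. With the shared core, the chloro-substituted aryl amide and the sulfonamide all kept, the expected step is a 1.1-fold higher number from compound 2 to compound 3 (0.03 log units; within the scatter), that is none beyond the scatter. The estimate for compound 3 in this assay is 3000 nM, within the range 1000 nM to 10000 nM.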

Compound 3, half-maximal inhibitory concentration: 3100 nM
For compound 3 the middle estimate is 1.0-fold (0.01 log units) below the measured one, and the stated range covers the measured number.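

Putting ethyl on the amide-type nitrogen of the urea gives a 1.1-fold higher number from compound 2 to compound 3 (0.04 log units; within the scatter) in this assay, so this assay does not separate hydrogen from ethyl at this position. The advantage over the 4-acetamido-3-methylphenyl group of compound 1 remains with ethyl in place: an at least 3.2-fold lower number from compound 1 to compound 3 (0.50 log units; beyond the scatter). That step can be read only as a bound, because the value of compound 1 is a limit and not a number: the limit of > 10000 nM in this assay, at which 1 of the 3 values shown sits.

Going by these compounds, whether this nitrogen accepts groups beyond ethyl stays open, such as a longer chain like butyl, a cyclopropyl ring, or a chain ending in an amine or a carboxylic acid. It is also unclear whether the urea or the absence of the methyl group accounts for the difference from compound 1, as the two change together.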